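Methyl for fluoro on the anilinic ring of compound 3

The compounds below may be only part of what the source reports. "The series", "measured", "known", "first", "only" and "open" are said of these compounds alone.

The series shares an imidazoline-bearing aniline core. Compound 1 `COc1ccc(S(C)(=O)=O)c(NCC2=NCCN2)c1` gives 14.1 nM in a functional assay for agonist activity at Alpha-1A adrenergic receptor (Homo sapiens); a higher number here means that more compound is needed for the effect, a lower number that less compound is needed. Compound 2 `CSc1ccc(C)cc1NCC1=NCCN1` gives 0.11 nM in this assay. Compound 3 `CS(=O)(=O)c1ccc(F)cc1NCC1=NCCN1` gives 16.6 nM: the highest of the three numbers, close to compound 1 and far from compound 2. For the measured compounds named here, the only single-point step measured so far is a 1.2-fold higher number from compound 1 to compound 3 (0.07 log units; within the scatter); fluoro and methoxy at that position are thus indistinguishable here.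

Compound 4 `Cc1ccc(S(C)(=O)=O)c(NCC2=NCCN2)c1` differs from compound 3 by methyl in place of fluoro on an aromatic carbon. Going by the values given here, the step from compound 1 to compound 3 bears on it as the only exchange at this carbon, and it stayed within the scatter. Compound 2 also carries methyl at this carbon, but its methylthio group is a second difference, so its value cannot be assigned to the methyl alone. The step of a 1.7-fold lower number from compound 3 to compound 4 (0.22 log units; within the scatter) is therefore expected to stay within the scatter, leaning slightly lower. Compound 4 is estimated at 10 nM, with a range from 3 nM to 40 nM.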

Compound 4, half-maximal effective concentration: 1.95 nM
Beside the measured number, compound 4's estimate is 5.1-fold (0.71 log units) above it; the measured number lies below the stated range.
By their numbers in this assay, from the lowest: compound 2; then compound 4; then compounds 1 and 3 (each within the scatter of the next).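

In this assay, for the compounds shown here, this carbon para to a methylsulfonyl group is not indifferent to its substituent: methyl in place of fluoro gives an 8.5-fold lower number from compound 3 to compound 4 (0.93 log units; beyond the scatter) and methyl in place of methoxy gives a 7.2-fold lower number from compound 1 to compound 4 (0.86 log units; beyond the scatter) while fluoro and methoxy themselves remain within the scatter of each other, with a 1.2-fold higher number from compound 1 to compound 3 (0.07 log units; within the scatter) as their only step. With methyl held at this carbon, methylsulfonyl in place of methylsulfanyl gives an 18-fold higher number from compound 2 to compound 4 (1.25 log units; beyond the scatter) so the low number of compound 2 cannot be credited to the methyl alone.

No supporting data bear on why methyl separates from fluoro and methoxy at this carbon. From the compounds shown here alone, whether ethyl, chloro or an amine at this carbon would track methyl stays open, as does whether the methylsulfanyl group would keep its lower number with fluoro or methoxy there.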